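From pyrrolidin-1-yl to piperidin-1-yl at the assay limit

The compounds below may be only part of what the source reports. "The series", "measured", "known", "first", "only" and "open" are said of these compounds alone.

Of the compounds shown here, two have been tested in a functional assay on DU-145 cells (Homo sapiens) for inhibition, read by MTT assay, with a stated time of 48 h (a higher number here means a weaker inhibitor, a lower number a stronger inhibitor), and neither gave a true number. Compound 1 `Cn1c(/C=C2\SC(=O)N(CC(=O)N3CCCCC3)C2=O)nc2ccccc21` reads > 50000 nM, which is a limit of the assay and not a number. Compound 2 `CC(C)n1c(/C=C2\SC(=O)N(CC(=O)N3CCCC3)C2=O)nc2ccccc21` reads > 50000 nM, which is also only a limit. Compound 2 therefore has no rank of its own: the limit of > 50000 nM in this assay, at which 2 of the 2 values shown sit.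

Compound 3 `CC(C)n1c(/C=C2\SC(=O)N(CC(=O)N3CCCCC3)C2=O)nc2ccccc21` differs from compound 2 in one place, with piperidin-1-yl in place of pyrrolidin-1-yl on a carbonyl carbon. For the measured compounds named here, no pair of measured compounds here shows what this swap does, so there is no measured step to lean on. Because compound 2 sits at > 50000 nM a modest expectation is the sensible one, with no shift beyond the scatter in either direction in this assay. The expected change, a number no higher from compound 2 to compound 3 (the limit leaves the size open), is estimated to stay within the usual scatter. For compound 3 the expected half-maximal inhibitory concentration is 50000 nM, with an estimated range from 20000 nM to 100000 nM, and the most likely report is again only a limit.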

Compound 3, half-maximal inhibitory concentration: 42200 nM
Compound 3: the middle estimate sits 1.2-fold (0.07 log units) above what was measured; low and high end bracket the measured number.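

Compound 3 is the only one of the three with a true number in this assay, 42200 nM, so the two changes that lead to it can now be read. Piperidin-1-yl in place of pyrrolidin-1-yl on a carbonyl carbon gives an at least 1.1-fold lower number from compound 2 to compound 3 (0.07 log units; that floor lies within the scatter), and isopropyl in place of methyl on an aromatic nitrogen gives an at least 1.1-fold lower number from compound 1 to compound 3 (0.07 log units; that floor lies within the scatter). These steps are floors and not true sizes, so neither change can yet be said to matter, because the other two compounds stand only at a limit of the assay: the limit of > 50000 nM in this assay, at which 2 of the 3 values shown sit.

From the compounds shown here alone, how far the true values of compound 1 and compound 2 lie from that of compound 3 stays open, so the real size of either step is unknown. Also open, going by these compounds, is how a morpholin-4-yl or a diethylamino group on that carbonyl carbon, or an ethyl or a benzyl group on the aromatic nitrogen, would read in this test.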